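A few compounds are considered here, and "the series" means these few. Any claim that something is new, unique, unknown or untested is made for them only; others in the source may bear on it.

Compound 1 `CNC(=O)c1cc(-c2cnc(NCc3c(F)ccc4c3CCO4)c3cn[nH]c(=O)c23)n(C)n1` has been measured in a physicochemical assay for lipophilicity, using the shake flask method, in phosphate buffer, measured as octanol-water partition, with a stated time of 30 min, at pH 7.4 (on this read-out higher numbers stand for higher lipophilicity and lower numbers for lower lipophilicity), and gives 2.1. Going by the values given here, of the two compounds measured so far, compound 1 stands lowest. Compound 2 `Fc1ccc2c(c1CNc1ncc(Oc3ccccc3)c3nncn13)CCO2` shares part of its structure with compound 1 but carries a different core; in this assay compound 2 gives 3.5, a higher number, and the gap between the two lies beyond the usual scatter of repeated measurements.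

Compound 3 `CNC(=O)c1ncc(-c2cnc(NCc3c(F)ccc4c3CCO4)c3cn[nH]c(=O)c23)n1C` has not yet been measured. It keeps the shared core of compound 1 and has the same atoms, joined differently; the change is 1-methyl-2-(methylcarbamoyl)-1H-imidazol-5-yl in place of 1-methyl-3-(methylcarbamoyl)-1H-pyrazol-5-yl on an aromatic carbon. Among the compounds with values here, no pair of measured compounds shows what such a change does, so the expectation rests on the fact that nothing is added or removed: the same five-membered aromatic ring with 2 hetero atoms and the same methylcarbamoyl group remain. In this assay the expected step is a number 0.20 log units lower from compound 1 to compound 3 (within the scatter), small and downward, or none beyond the scatter. Compound 3 is therefore estimated at 1.9, with a likely range from 1.4 to 2.4.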

Compound 3, distribution coefficient: 2.5
Compound 3: middle estimate off by 0.60 log units, on the low side, outside the stated range (above it).
By their numbers in this assay, from the lowest: compound 1; then compound 3; then compound 2.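

In this assay the number moves by a number 0.40 log units higher from compound 1 to compound 3 (beyond the scatter) when 1-methyl-2-(methylcarbamoyl)-1H-imidazol-5-yl takes the place of 1-methyl-3-(methylcarbamoyl)-1H-pyrazol-5-yl on this aromatic carbon. The two groups have the same atoms and the same counts of donors and acceptors, so at this position the way the atoms are joined is enough to shift the result beyond the scatter, something compound 2, with its different core, could not show. Nothing available here explains why the number moves in this direction.

As far as these compounds go, this is a single pair on a single core, so it remains open whether the same exchange of rings would give a similar step on another core, or with another group on the five-membered ring. A nitrile or a carboxylic acid in place of the methylcarbamoyl group, for example, could show whether the step belongs to the ring itself or depends on what the ring carries.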